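Swapping a Piperidine Substituent on a Spiro Amide Core

A few compounds are considered here, and "the series" means these few. Any claim that something is new, unique, unknown or untested is made for them only; others in the source may bear on it.

Measured so far:
compound 1, `CC(C)(C)c1ccc(C(=O)N2CCC3(CC2)C(=O)N(CC(=O)N2CCCCC2CCO)CN3c2ccccc2)cc1`: 6100 nM
compound 2, `CC(C)(C)OC(=O)NCCCCNC(=O)CN1CN(c2ccccc2)C2(CCN(C(=O)c3ccc(C4CCCCC4)cc3)CC2)C1=O`: 4600 nM

Both compounds were tested in an assay on HEK293 cells for displacement of a labelled ligand from NPC1-like intracellular cholesterol transporter 1 (Homo sapiens); a higher number here means a weaker inhibitor, a lower number a stronger inhibitor. Compound 1 gives 6100 nM, and compound 2 gives 4600 nM. Compound 1 holds the higher of the two numbers, but the two values lie within the usual scatter of repeated measurements, so nothing can be said about which of the two is the stronger binder; both are weak.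

Compound 3, `CCOC(=O)C1CCCN(C(=O)CN2CN(c3ccccc3)C3(CCN(C(=O)c4ccc(C(C)(C)C)cc4)CC3)C2=O)C1`, has not yet been measured. It is built from compound 1 by one change, (3-(ethoxycarbonyl)piperidin-1-yl in place of 2-(2-hydroxyethyl)piperidin-1-yl on a carbonyl carbon). A hydroxyl-bearing chain on the piperidine is thus traded for an ester on the same kind of ring. Going by the values given here, no pair of measured compounds shows this particular change, so there is no measured step to lean on.

With only two weak binders in hand, the expected step of a 1.1-fold lower number from compound 1 to compound 3 (0.04 log units; within the scatter) from compound 1 to compound 3 is none beyond the scatter, in no set direction. For compound 3, the expected value in this assay is 5500 nM, with a range from 1800 nM to 17000 nM.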

Compound 3, half-maximal inhibitory concentration: 8200 nM
Beside the measured number, compound 3's estimate is 1.5-fold (0.17 log units) below it; the measured number falls inside the stated range.
By their numbers in this assay, from the lowest: compounds 2, 1 and 3 (each within the scatter of the next).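

In this assay, replacing 2-(2-hydroxyethyl)piperidin-1-yl with 3-(ethoxycarbonyl)piperidin-1-yl on a carbonyl carbon gives a 1.3-fold higher number from compound 1 to compound 3 (0.13 log units; within the scatter) and so no readable difference. Going by these compounds alone, this is the first comparison of two compounds that differ in only one place, and it shows that two quite different piperidine groups at this site give numbers that cannot be told apart: the group leaving has 1 hydrogen-bond donor and 9 heavy atoms, while the group entering has 0 hydrogen-bond donors and 11 heavy atoms. Within the data shown here, the result covers only this pair, and nothing measured here offers an explanation for it.

The swap alters the group on the piperidine ring and its place on that ring together, so a matched compound such as one bearing 3-(2-hydroxyethyl)piperidin-1-yl would be needed to separate the two changes. From the compounds shown here alone, it also remains open whether a carboxylic acid or a primary amine on the piperidine ring, or a different ring altogether, would move the number beyond the usual scatter in either direction.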